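A few compounds are considered here, and "the series" means these few. Any claim that something is new, unique, unknown or untested is made for them only; others in the source may bear on it.

Measured so far in a toxicity assay on HeLa cells (Homo sapiens) for cytotoxicity, read by MTT assay, with a stated time of 24 h; on this read-out lower numbers stand for stronger inhibition and higher numbers for weaker inhibition:
- compound 1, `Cc1ncc([N+](=O)[O-])n1CC(O)CSC(=S)N1CCN(c2cccc(Cl)c2Cl)CC1`: 1000000 nM
- compound 2, `Cc1ncc([N+](=O)[O-])n1CC(O)CSC(=S)N1CCC(C)CC1`: 1820000 nM
- compound 3, `CCOC(=O)N1CCN(CC(O)Cn2c([N+](=O)[O-])cnc2C)CC1`: 3670000 nM

Compound 3 stands at the highest of the three numbers. Its nearest neighbour is compound 2, whose value lies within the usual scatter of compound 3's, so no order between those two can be claimed. Compound 1 gives the lowest number of the three, and its gap to compound 3 is beyond the scatter. Within the data shown here, all three sit in a region of very weak cytotoxicity, and with only three compounds and no single-change pairs among them, no trend by substituent can be read from these numbers.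

Compound 4, `COc1ccccc1N1CCN(CC(O)Cn2c([N+](=O)[O-])cnc2C)CC1`, is not yet measured. It differs from compound 3 in one place: 2-methoxyphenyl in place of ethoxycarbonyl on an amine nitrogen in a ring. Among the measured compounds shown here, no measured pair shows this change, so its effect cannot be taken from a recorded step. For the measured compounds named here, the only anchor is that compound 1, which carries an aromatic ring on the shared core and gives 1000000 nM, sits lowest. On that basis a modest move of compound 4 toward lower numbers in this assay is expected, but the step may equally stay within the scatter.

For compound 4 the expected value in this assay is 1500000 nM, estimated to lie between 500000 nM and 5000000 nM. The step this estimate implies is expected to be a 2.4-fold lower number from compound 3 to compound 4 (0.39 log units; beyond the scatter).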

Compound 4, half-maximal inhibitory concentration: 4390000 nM
Estimate against measurement, compound 4: 2.9-fold (0.47 log units) below, and the stated range covers the measured number.
By their numbers in this assay, from the lowest: compounds 1, 2, 3 and 4 (each within the scatter of the next, the first and the last beyond it).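

Among these compounds, on the amine nitrogen in a ring of the six-membered non-aromatic ring with 2 nitrogen, 2-methoxyphenyl in place of ethoxycarbonyl gives a 1.2-fold higher number from compound 3 to compound 4 (0.08 log units; within the scatter) in this assay, the first single-change reading. At this place, a group with a six-membered aromatic ring of carbon only and a group with no ring therefore cannot be told apart on this read-out, so the change gives no ground for linking an aromatic ring here to a lower number. Nothing on hand offers an explanation for how these two groups compare.

Still open, as far as these compounds go, is whether a plain phenyl, a 2-chlorophenyl, an acetyl or a chain ending in a carboxylic acid on this nitrogen would separate from ethoxycarbonyl and 2-methoxyphenyl by more than the scatter, and whether the methoxy group on the phenyl ring contributes anything at all. Also open, from the compounds shown here alone, is whether the same exchange would give a comparable step on the sulfur-bearing linker shared by compound 1 and compound 2.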